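The source may hold more compounds than are shown below. What is called first, only, known or untested is meant among the compounds shown, and "the series" means these compounds.

Of the compounds shown here, two of a shared core have been tested in a functional assay on MCF7 cells (Homo sapiens) for cytotoxicity, read by MTT assay, with a stated time of 48 h; on this read-out lower numbers stand for stronger inhibition and higher numbers for weaker inhibition. Compound 1, `COc1cc(-c2cc(C(=O)Nc3nc4ccc(F)cc4s3)nc3cc(-c4ccccc4)nn23)cc(OC)c1OC`, gives 27500 nM. Compound 2, `COc1ccc(-c2cc(C(=O)Nc3nc4ccc(OC)cc4s3)nc3cc(-c4ccccc4)nn23)cc1`, gives 19100 nM in this assay, the lower of the two numbers, though the gap to compound 1 lies within the scatter of repeated measurements, so the two cannot be ranked against each other. The two compounds differ in two places at once, so neither difference can be read on its own.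

Compound 3, `COc1ccc2nc(NC(=O)c3cc(-c4cc(OC)c(OC)c(OC)c4)n4nc(-c5ccccc5)cc4n3)sc2c1`, has not yet been measured. It keeps the methoxy-bearing part of compound 2 and changes the other end: 3,4,5-trimethoxyphenyl in place of 4-methoxyphenyl on an aromatic carbon. Going by the values given here, the only guide to this change is compound 1, which also carries the 3,4,5-trimethoxyphenyl and gives 27500 nM, a number that does not part from compound 2 beyond the scatter. For that reason no step beyond the scatter is expected from compound 2 to compound 3, and a 1.2-fold higher number from compound 2 to compound 3 (0.06 log units; within the scatter) is what the estimate means. Compound 3 is expected to give about 22000 nM in this assay, within a range from 9000 nM to 55000 nM.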

Compound 3, half-maximal inhibitory concentration: 2950 nM
Compound 3: middle estimate off by 7.5-fold (0.87 log units), on the high side, and the stated range ends above it.
By their numbers in this assay, from the lowest: compound 3; then compounds 2 and 1 (each within the scatter of the next).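

In this assay, with the methoxy-bearing end held fixed, 3,4,5-trimethoxyphenyl in place of 4-methoxyphenyl on an aromatic carbon gives a 6.5-fold lower number from compound 2 to compound 3 (0.81 log units; beyond the scatter), so this position can move the number on its own, something the two-place difference between compound 1 and compound 2 could not show. With 3,4,5-trimethoxyphenyl held fixed, methoxy in place of fluoro on an aromatic carbon gives a 9.3-fold lower number from compound 1 to compound 3 (0.97 log units; beyond the scatter), so the other end of the molecule matters as well, and the trimethoxyphenyl group alone does not set the number. Nothing measured here says why either change lowers the number.

Still open, on these data alone, is whether all three methoxy groups are needed, which a dimethoxyphenyl or a plain phenyl at this position would help to settle. Also open, as far as these compounds go, is whether the two changes depend on each other, which the pairing of 4-methoxyphenyl with fluoro would test, and whether a chloro or a hydroxy group could take the place of the methoxy at the other end.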